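The source may report more compounds than this note shows. Statements on the series, on what has been measured and on what is new or still open speak of the compounds shown alone.

Measured so far:
compound 1, `COc1cc2c(cc1OC)C(CC(=O)NC(C)(C)C)CC2` — 41.8%
compound 2, `COc1cc2c(cc1OC)C(CC(=O)NCc1ccccc1)CC2` — 48.1%

Both compounds were tested in a functional assay on the whole organism (strain Swiss albino) for inhibition, with Mus musculus as the target, in the writhing test, with stated times of 60 min and 15 min, at a dose of 100 mg/kg by the oral route; a higher number here means more inhibition at the dose given (going by the name of the read-out), a lower number less inhibition. Compound 1 gives 41.8%, and compound 2 gives 48.1%. Going by the values given here, compound 2 holds the higher of the two numbers, but the only measured step, a number 6.3 percentage points higher from compound 1 to compound 2 (within the scatter), lies within the scatter, so the two values cannot be told apart with confidence.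

Compound 3, `COc1cc2c(cc1OC)C(CC(=O)N1CCCC1)CC2`, has not yet been measured. It differs from compound 2 in one place: pyrrolidin-1-yl in place of benzylamino on a carbonyl carbon. Among the compounds with values here, the one known step bears on this change only loosely, as it also swaps the group on the amide-type nitrogen and was small. With no other guide, the expectation for compound 3 is a step of a number 6.1 percentage points lower from compound 2 to compound 3 (within the scatter), that is no change beyond the scatter. Compound 3 is therefore estimated at 42%, within a range from 25% to 58%.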

Compound 3, a percentage reported as inhibition, in the whole organism at one dose (the size of the read-out at that dose, not a potency): 19.2%
Estimate against measurement, compound 3: 22.8 percentage points above, outside the stated range (below it).
By their numbers in this assay, from the lowest: compound 3; then compounds 1 and 2 (each within the scatter of the next).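

Replacing either open-chain amine on the carbonyl carbon with pyrrolidin-1-yl gives a number 28.9 percentage points lower from compound 2 to compound 3 (beyond the scatter) and a number 22.6 percentage points lower from compound 1 to compound 3 (beyond the scatter) in this assay and so shows that this position can respond clearly to the choice of group, which the small earlier step between benzylamino and (tert-butyl)amino did not reveal. The counted difference is that benzylamino brings 1 hydrogen-bond donor and pyrrolidin-1-yl brings 0, while the nitrogen also becomes part of a five-membered ring. Nothing measured here explains the lower number.

Whether the lower number goes with the ring or with the missing amide hydrogen remains open, as the compounds shown include no open-chain diethylamino group, which also lacks that hydrogen. How ring size or a further ring atom would read is also unsettled, with piperidin-1-yl and morpholin-4-yl absent from this set.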